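Replacing the aryl urea tail of compound 1 with a polyol semicarbazide

The source may report more compounds than this note shows. Statements on the series, on what has been measured and on what is new or still open speak of the compounds shown alone.

Measured compounds:
compound 1 `COc1cc(NC(C)CCCNC(=O)Nc2ccc(Cl)c(C(F)(F)F)c2)c2ncccc2c1`, 3400 nM
compound 2 `NNC(=O)NC(c1ccccc1)c1ccc(Cl)cc1`, >= 250000 nM

Of the compounds shown here, two have been tested in a functional assay on MOLT-4 cells (Homo sapiens) for inhibition, read by MTT assay, with a stated time of 4 days; a lower number here means a stronger inhibitor, a higher number a weaker inhibitor. Among the compounds with values here, compound 1 `COc1cc(NC(C)CCCNC(=O)Nc2ccc(Cl)c(C(F)(F)F)c2)c2ncccc2c1` gives 3400 nM, and this is the only plain number in the set. For compound 2 `NNC(=O)NC(c1ccccc1)c1ccc(Cl)cc1` the assay returns only a limit, >= 250000 nM, so no number is known for it; the set therefore has one numbered value and one value that sits at the limit of >= 250000 nM in this assay, at which 1 of the 2 values shown sits. Within the data shown here, no step between two measured compounds that differ in a single place is available, so nothing measured tells how a change at the urea tail shifts the read-out.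

Compound 3 `COc1cc(NC(C)CCCNC(=O)NNC(=O)NC(CO)(CO)CO)c2ncccc2c1` is not yet measured. It differs from compound 1 by ((2-hydroxy-1,1-bis(hydroxymethyl)ethyl)carbamoyl)amino in place of 4-chloro-3-(trifluoromethyl)phenyl on an amide-type nitrogen. Among the measured compounds shown here, with no measured step of this kind to lean on, the change is large in kind and is expected to weaken inhibition well beyond the usual scatter. Compound 3 is expected to give about 100000 nM, within a range from 20000 nM to 250000 nM. The expected step is a 29-fold higher number from compound 1 to compound 3 (1.47 log units; beyond the scatter), toward a weaker inhibitor.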

Compound 3, half-maximal inhibitory concentration: > 250000 nM
Compound 3 gave a limit, no number; the forecaster's own chance of this, stated with the estimate: 50%; middle value at least 2.5-fold (0.39 log units) away from the limit.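

In this assay, within the data shown here, placing ((2-hydroxy-1,1-bis(hydroxymethyl)ethyl)carbamoyl)amino instead of 4-chloro-3-(trifluoromethyl)phenyl on the amide-type nitrogen gives an at least 73-fold higher number from compound 1 to compound 3 (1.86 log units; beyond the scatter), the first measured step at this position, and it lies beyond the scatter. From the compounds shown here alone, the reading for compound 3 is a limit of the assay and not a number, so the true size of the step is unknown: the limit of > 250000 nM in this assay, at which 1 of the 3 values shown sits. This position therefore does not accept every group of this size, since both groups have 11 heavy atoms, yet only compound 1 gives a number, although the swap also removes the aromatic ring and brings in 5 hydrogen-bond donors at once, so this single pair cannot show which of these differences matters.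

Going by these compounds, whether the chlorine and trifluoromethyl substituents are needed, or the aromatic ring alone is enough, stays open until an unsubstituted phenyl is compared at this nitrogen. On these data alone, it is equally open whether a non-aromatic group such as a cyclohexyl, or a simple tert-butyl without the three hydroxyl groups, would keep a measurable inhibition.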